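This account rests on a few compounds, and the source may have more. Where it says the series, first, only, none or still open, it means among the compounds named here.

Compound 1 `Cn1cnc2c(N3CCCCC3)nc(-c3cc(Cl)ccc3Cl)nc21` is the starting point. In an assay on cells for displacement of a labelled ligand from adenosine receptor A1 (Homo sapiens), read by scintillation counting and radioligand binding, with a stated time of 60 min, tested at 10 uM (on this read-out higher numbers stand for more inhibition at the one concentration tested (going by the name of the read-out) and lower numbers for less inhibition), compound 1 gives 13.2%, the higher of the two numbers measured here, with compound 2 `Clc1ccc(Cl)c(-c2nc(N3CCCCC3)c3nc[nH]c3n2)c1` as its nearest neighbour at 1.4%. The step of a number 11.8 percentage points lower from compound 1 to compound 2 (beyond the scatter) comes from hydrogen in place of methyl on an aromatic nitrogen, which lies beyond the usual scatter but is modest.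

Compound 3 `Cn1cnc2c(N3CCCCC3)nc(-c3ccccc3Cl)nc21` has not been measured. It differs from compound 1 by hydrogen in place of chloro on an aromatic carbon: the chloro group on an aromatic carbon of the six-membered carbon-only ring is gone, so that 2,5-dichlorophenyl becomes 2-chlorophenyl. Within the data shown here, no measured step touches this part of the molecule; the only measured step concerns the methyl on the aromatic nitrogen, so it gives no direct guide. Compound 3 is therefore expected to stay near compound 1, with a step of a number 5.2 percentage points lower from compound 1 to compound 3 (within the scatter) in this assay. The estimate for compound 3 is 8%, within -5% to 25%.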

Compound 3, a percentage reported as inhibition, at one concentration (the size of the read-out at that concentration, not a potency): 35.2%
Beside the measured number, compound 3's estimate is 27.2 percentage points below it; measured number above the stated range.
By their numbers in this assay, from the lowest: compound 2; then compound 1; then compound 3.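

Removing the chloro group that sits para to a chloro group on the six-membered carbon-only ring gives a number 22 percentage points higher from compound 1 to compound 3 (beyond the scatter) in this assay and so shows that this part of the molecule can move the number. Among these compounds, of the two single changes made to compound 1, this is the one that raises the reading, whereas the change on the aromatic nitrogen gives a number 11.8 percentage points lower from compound 1 to compound 2 (beyond the scatter) as its step. Nothing measured here explains why losing this chloro group has this effect.

At this place, only chloro and hydrogen can be compared so far, which leaves open how a methoxy group, a fluorine atom or an amine would read. From the compounds shown here alone, it also remains open whether the remaining chloro group of the 2-chlorophenyl ring contributes to the reading, and whether removing the methyl from compound 3 would again lower it.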